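Adding a Methoxy to the Core of Compound 3

The source may hold more compounds than are shown below. What is called first, only, known or untested is meant among the compounds shown, and "the series" means these compounds.

The measured compounds:
Compound 1, `COc1cc(CC(O)(COCc2ccccc2)COCc2ccccc2)nc(OC)n1`, in a functional assay on HeLa cells (Homo sapiens) for antiproliferative activity, read by MTT assay, with a stated time of 72 h (on this read-out lower numbers stand for stronger inhibition and higher numbers for weaker inhibition), gives > 100000 nM, which is a limit of the assay and not a number.
Compound 2, `COc1cc(CC(COCc2ccccc2)COCc2ccccc2)nc(OC)n1`, gives 3500 nM.
Compound 3, `COc1cc(CC(O)COCc2ccccc2)nc(OC)n1`, gives > 100000 nM, again a limit of the assay.

Compound 3 therefore stands at the edge of what this assay can report, and it is not alone there: the limit of > 100000 nM in this assay, at which 2 of the 3 values shown sit. Compound 2 is the only one of the three with a real number.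

Compound 4, `COc1nc(CC(O)COCc2ccccc2)c(OC)c(OC)n1`, is compound 3 with one change: methoxy in place of hydrogen on an aromatic carbon. The measured steps all concern the chain, not the ring. There is an at least 28-fold lower number from compound 1 to compound 2 (1.45 log units; beyond the scatter), there is an at least 28-fold higher number from compound 2 to compound 3 (1.45 log units; beyond the scatter), and there is a step that the two limits leave unreadable from compound 1 to compound 3. None of these steps alters the aromatic ring, so none of them speaks directly to the change from compound 3 to compound 4, and the limit for compound 3 leaves no firm starting number.

With nothing to push the estimate in either direction, the step is expected to be a number no higher from compound 3 to compound 4 (the limit leaves the size open), that is, no readable movement. Compound 4 is accordingly estimated at 100000 nM, with a range from 15000 nM to 500000 nM, and most likely the assay again reports only a limit for compound 4.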

Compound 4, half-maximal inhibitory concentration: > 100000 nM
Compound 4: only a limit was reported (the forecaster's own chance of this, stated with the estimate: 75%); the middle value lies on the limit itself.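

Compound 3 and compound 4 each give only a limit and not a number, so no step can be read between them. Compound 4 joins the compounds already at that edge: the limit of > 100000 nM in this assay, at which 3 of the 4 values shown sit. The compounds shown leave open whether methoxy in place of hydrogen on an aromatic carbon changes activity at all.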